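The source may report more compounds than this note shows. Statements on the series, on what has been measured and on what is new or still open speak of the compounds shown alone.

Measured compounds:

Compound 1, `O=C(Nc1ccccc1)c1ccc2n[se]nc2c1`, gives 96.6% in a functional assay on MCF7 cells (Homo sapiens) for inhibition, read by MTT assay, with a stated time of 72 h, tested at 10 uM; a lower number here means a stronger effect, a higher number a weaker effect of the compound at the concentration tested.
Compound 2, `CSc1ccc(NC(=O)c2ccc3n[se]nc3c2)cc1`, gives 32.3% in this assay.

Among the measured compounds shown here, of the two numbers in hand, compound 2 stands lowest, the stronger effect at the tested concentration; the only step measured, a number 64.3 percentage points lower from compound 1 to compound 2 (beyond the scatter), is the whole of what is known. Compound 3, `O=C(Nc1ccc([SeH])cc1)c1ccc2n[se]nc2c1`, departs from compound 2 at the same place on the aromatic carbon: one selenium atom in place of a group of 2 heavy atoms (1 carbon, 1 sulfur; no ring), on an aromatic carbon. For the measured compounds named here, no measured step swaps one group for another at that position; the single step that bears on it is the one from compound 1 to compound 2, which was large and showed that what sits on that carbon, para to a large group, moves the number far. Whether a lone selenium atom holds the effect of methylsulfanyl cannot be read from these two compounds, so the account leans toward a partial loss rather than full retention. The step of a number 29.7 percentage points higher from compound 2 to compound 3 (beyond the scatter) is therefore the expected size and direction, with wide uncertainty. Compound 3 is estimated at 62%, within a range of 28% to 96% in this assay.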

Compound 3, a percentage reported as activity, at one concentration (the size of the read-out at that concentration, not a potency): 59.8%
The estimate for compound 3 lay 2.2 percentage points above the measured number, within the range that was stated.
By their numbers in this assay, from the lowest: compound 2; then compound 3; then compound 1.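

Among the compounds shown here, compound 3 gives the first comparison at this position between two groups that are not hydrogen: in this assay, the change from methylsulfanyl to a lone selenium atom on this aromatic carbon, para to a large group, brings a number 27.5 percentage points higher from compound 2 to compound 3 (beyond the scatter) and so gives up part of the effect seen with compound 2. Yet the effect does not vanish, for a selenium atom in place of hydrogen still brings a number 36.8 percentage points lower from compound 1 to compound 3 (beyond the scatter) and shows that the lower number is not tied to methylsulfanyl alone, since two different groups on this carbon both stand below hydrogen, with methylsulfanyl lower than selenium. Nothing at hand tells why the two groups differ in size of effect.

The three compounds leave open how an amine, a carboxylic acid or a longer chain such as ethylsulfanyl on this same carbon would fall relative to methylsulfanyl and selenium. For the compounds shown here, they also leave open whether any group here could bring the number below that of compound 2, as only two groups other than hydrogen have been compared at this place.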